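The compounds below may be only part of what the source reports. "The series", "measured", "known", "first", "only" and "open" are said of these compounds alone.

Two compounds built on one shared core have been examined in an assay on cell membranes for displacement of a labelled ligand from Neuronal acetylcholine receptor; alpha4/beta2 (Rattus norvegicus), read by scintillation counting, with a stated time of 2 h, tested at 5 uM; on this read-out lower numbers stand for less inhibition and higher numbers for more inhibition at the one concentration tested (going by the name of the read-out). Compound 1 `Nc1c(C2=NC3(CN2)CN2CCC3CC2)oc2ccccc12` gives 9% in this assay. Compound 2 `c1ccc(C2=NC3(CN2)CN2CCC3CC2)cc1` gives 11% in this assay, the higher of the two numbers, though its gap to compound 1 lies within the usual scatter, so the two compounds cannot be told apart on these data. Both numbers are small, meaning only weak displacement of the labelled ligand at the single concentration tested.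

Compound 3 `Oc1ccccc1C1=NC2(CN1)CN1CCC2CC1` has not yet been measured. It differs from compound 2 by hydroxy in place of hydrogen on an aromatic carbon. Among the compounds with values here, no pair of measured compounds shows what such a change does here, so the expectation rests on the low numbers of compound 1 and compound 2 alone. The step of a number 1 percentage points higher from compound 2 to compound 3 (within the scatter) is expected to be small, with no change beyond the scatter. Compound 3 is therefore estimated at 12% in this assay, within a range from 0% to 28%.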

Compound 3, a percentage reported as inhibition, at one concentration (the size of the read-out at that concentration, not a potency): 4%
Compound 3: the middle estimate sits 8 percentage points above what was measured; low and high end bracket the measured number.
By their numbers in this assay, from the lowest: compounds 3, 1 and 2 (each within the scatter of the next).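

In this assay hydroxy in place of hydrogen on an aromatic carbon, ortho to a large group, gives a number 7 percentage points lower from compound 2 to compound 3 (within the scatter). Within the data shown here, this is the first change here that can be read between two compounds differing in one place, and it shows that adding this one group does not lift the weak displacement beyond the scatter, so compound 3 cannot be told apart from compound 2. No measurement shown here bears on the reason for this result.

As far as these compounds go, it remains open whether a different group on this same carbon, such as an amine, a methoxy group or a carboxylic acid, would move the number beyond the scatter. With every number this small at a single concentration, the behaviour of these compounds at other concentrations also remains open.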